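Amide aryl swap on an azo-indole scaffold

A few compounds are considered here, and "the series" means these few. Any claim that something is new, unique, unknown or untested is made for them only; others in the source may bear on it.

Compound 2 `O=C(Nc1ccccc1F)c1ccc(/N=N\c2c[nH]c3ccccc23)cc1` stands highest of the two numbers measured in a functional assay on HCT-116 cells (Homo sapiens) for inhibition, read by MTT assay, with a stated time of 72 h (a higher number here means a weaker inhibitor, a lower number a stronger inhibitor), where compound 2 gives 559000 nM. For the measured compounds named here, compound 1 `Cc1ccc(NC(=O)c2ccc(/N=N\c3c[nH]c4ccccc34)cc2)cc1` carries 4-methylphenyl on the same amide-type nitrogen and in this assay compound 1 gives 25400 nM; the single measured step, a 22-fold higher number from compound 1 to compound 2 (1.34 log units; beyond the scatter), shows that exchanging the aryl group on this nitrogen moves the number far beyond the scatter. Compound 3 `O=C(Nc1ccc([N+](=O)[O-])cc1)c1ccc(/N=N\c2c[nH]c3ccccc23)cc1` is not yet measured; it differs from compound 2 in one place: 4-nitrophenyl in place of 2-fluorophenyl on an amide-type nitrogen. Going by the values given here, no measured step involves a nitro group, so the only guidance is that this position is sensitive and that compound 1, whose aryl group is also a phenyl with one substituent placed as in 4-methylphenyl, gave 25400 nM. A lower number than compound 2 is therefore expected for compound 3, though with wide uncertainty, and the step of an 11-fold lower number from compound 2 to compound 3 (1.05 log units; beyond the scatter) is the estimate for that change. In this assay compound 3 is estimated at 50000 nM, within a range from 6000 nM to 400000 nM.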

Compound 3, half-maximal inhibitory concentration: 156000 nM
The estimate for compound 3 lay 3.1-fold (0.49 log units) below the measured number; the range from low to high includes it.
By their numbers in this assay, from the lowest: compound 1; then compound 3; then compound 2.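

In this assay, the exchange on the amide-type nitrogen now has a second measured outcome: a 3.6-fold lower number from compound 2 to compound 3 (0.55 log units; beyond the scatter), so 4-nitrophenyl closes only part of the gap that separates 2-fluorophenyl from 4-methylphenyl. The cleaner comparison changes a single group on an aromatic carbon, nitro in place of methyl, and gives a 6.1-fold higher number from compound 1 to compound 3 (0.79 log units; beyond the scatter), which shows that the number depends on the identity of that group and not only on the presence of a substituted phenyl on the nitrogen. The information available offers no measured basis for explaining either step.

The step from 2-fluorophenyl to 4-nitrophenyl changes both the substituent and its numbered place on the ring, so the compounds shown cannot separate those two contributions. They also leave open how an unsubstituted phenyl, or an amine or a carboxylic acid in place of the nitro group, would stand against compound 1, and whether any group on this aryl ring can give a lower number than the methyl group does.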